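The source may report more compounds than this note shows. Statements on the series, on what has been measured and on what is new or still open speak of the compounds shown alone.

Measured compounds in a functional assay on the whole organism (Pleural cavity) for inhibition, with Rattus norvegicus as the target, at a dose of 25 mg/kg; a lower number here means less inhibition, a higher number more inhibition at the dose given (going by the name of the read-out):
compound 1 `COc1ccc(N2C(=O)C(C)(C)c3cccnc32)cc1`, 42%
compound 2 `C[S+]([O-])c1ccc(N2C(=O)C(C)(C)c3cccnc32)cc1`, 0%
compound 3 `CC1(C)C(=O)N(c2ccc(Br)cc2)c2ncccc21`, 55%

Compound 3 stands highest of the three numbers in this assay. Compound 1 is the nearest to it, the step being a number 13 percentage points higher from compound 1 to compound 3 (beyond the scatter), and compound 2 the furthest, with a number 55 percentage points higher from compound 2 to compound 3 (beyond the scatter). For the measured compounds named here, the only other measured step, a number 42 percentage points lower from compound 1 to compound 2 (beyond the scatter), is the large fall that comes with the sulfur-containing group.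

Compound 4 `CC(C)c1ccc(N2C(=O)C(C)(C)c3cccnc32)cc1` differs from compound 3 by isopropyl in place of bromo on an aromatic carbon. Going by the values given here, no measured step compares bromo with a carbon-only group, so the bearing of the measured steps is indirect. Among the compounds with values here, the one step that changes bromo against a small uncharged group, a number 13 percentage points higher from compound 1 to compound 3 (beyond the scatter), was modest; the large shifts, a number 42 percentage points lower from compound 1 to compound 2 (beyond the scatter) and a number 55 percentage points higher from compound 2 to compound 3 (beyond the scatter), both involve the sulfur-containing group, which is not part of the present change. The expectation for compound 4 in this assay is therefore a step of about a number 5 percentage points lower from compound 3 to compound 4 (within the scatter), that is, none beyond the scatter, with a slight lean downward.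

Compound 4 is estimated to give about 50% in this assay, with a likely range from 30% to 65%.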

Compound 4, a percentage reported as inhibition, in the whole organism at one dose (the size of the read-out at that dose, not a potency): 6%
For compound 4 the middle estimate is 44 percentage points above the measured one, outside the stated range (below it).
By their numbers in this assay, from the lowest: compounds 2 and 4 (each within the scatter of the next); then compound 1; then compound 3.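

In this assay, the aromatic carbon para to a large group proves sensitive to a change that involves no sulfur: a number 49 percentage points lower from compound 3 to compound 4 (beyond the scatter), so a large shift here is not confined to the sulfur-containing group. Isopropyl also compares poorly with methoxy, with a number 36 percentage points lower from compound 1 to compound 4 (beyond the scatter), whereas a number 6 percentage points higher from compound 2 to compound 4 (within the scatter) leaves isopropyl not distinguishable from the sulfur-containing group at this dose, and only bromo and methoxy among the four groups retain a clear read-out. Bromo and isopropyl both count no hydrogen-bond donors or acceptors and carry no net charge, so these counts do not separate them, and no measurement at hand accounts for the fall.

As far as these compounds go, it remains open whether the loss belongs to isopropyl alone or to carbon-only groups in general, which methyl or a longer chain such as n-butyl in this place would help to settle. Also open, from the compounds shown here alone, is whether the level seen with bromo is particular to bromine or shared with chloro or fluoro, and whether an amine here would read like methoxy.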